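Moving the chlorine around the benzyl group bound to sulfur

This account rests on a few compounds, and the source may have more. Where it says the series, first, only, none or still open, it means among the compounds named here.

Three compounds sharing one core were tested in a functional assay on the whole organism (artery, strain albino) with Rattus norvegicus as the target, with a stated time of 720 min, at a dose of 10 mg/kg by the oral route; on this read-out lower numbers stand for less inhibition and higher numbers for more inhibition at the one dose given (going by the name of the read-out). Compound 1 `CC1=C(C(=O)Nc2ccc(Br)cc2)C(c2ccc(Cl)cc2Cl)N=C(SCc2ccc(Cl)cc2)N1` gives 25.8%. Compound 2 `COc1ccc(C2N=C(SCc3ccccc3Cl)NC(C)=C2C(=O)Nc2ccc(Br)cc2)cc1` gives 10.8%. Compound 3 `COc1ccc(C2N=C(SCc3cccc(Cl)c3)NC(C)=C2C(=O)Nc2ccc(Br)cc2)cc1` gives 26.8%, the top of the three numbers, although compound 1 lies within the scatter of it. Among the measured compounds shown here, the only measured step that alters just the benzyl group, a number 16 percentage points higher from compound 2 to compound 3 (beyond the scatter), was beyond the scatter. Compound 4 `COc1ccc(C2N=C(SCc3ccc(Cl)cc3)NC(C)=C2C(=O)Nc2ccc(Br)cc2)cc1` differs from compound 3 by 4-chlorophenyl in place of 3-chlorophenyl on a saturated chain carbon bound to a sulfur. For the measured compounds named here, no measured step covers this exact change; compound 1 carries the same 4-chlorobenzyl group but differs elsewhere, so its value is only a hint. The step of a number 2.8 percentage points lower from compound 3 to compound 4 (within the scatter) is therefore expected to stay within the scatter. The estimate for compound 4 in this assay is 24%, between 10% and 38%.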

Compound 4, a percentage reported as inhibition, in the whole organism at one dose (the size of the read-out at that dose, not a potency): 23.7%
Estimate against measurement, compound 4: 0.3 percentage points above; the measured number falls inside the stated range.
By their numbers in this assay, from the lowest: compound 2; then compounds 4, 1 and 3 (each within the scatter of the next).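

Within this assay, 3-chlorophenyl and 4-chlorophenyl on a saturated chain carbon bound to a sulfur cannot be told apart (a number 3.1 percentage points lower from compound 3 to compound 4 (within the scatter)). The 2-chlorophenyl group now differs from both of them, not only from the 3-chlorophenyl group (a number 12.9 percentage points higher from compound 2 to compound 4 (beyond the scatter)). With the 4-chlorobenzyl group held constant, 4-methoxyphenyl in place of 2,4-dichlorophenyl on a saturated ring carbon also gives no clear change (a number 2.1 percentage points lower from compound 1 to compound 4 (within the scatter)).

No measurement here accounts for the lower number of compound 2. From the compounds shown here alone, whether a plain benzyl group without chlorine, or a longer chain carrying an amine, would keep the number at this level remains open.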